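The source may hold more compounds than are shown below. What is called first, only, known or untested is meant among the compounds shown, and "the series" means these compounds.

In a functional assay on KB cells (Homo sapiens) for inhibition (a lower number here means a stronger inhibitor, a higher number a weaker inhibitor), compound 1 `Nc1nc2cc(Cl)c(Cl)cc2n1COCCO` returns only > 100000 nM, a limit of the assay rather than a number. Compound 2 `Nc1nc2c(Cl)cc(Cl)cc2n1COCCO` likewise sits at the limit > 100000 nM in this assay. Compound 3 `CNc1nc2c(Cl)cc(Cl)cc2n1COCCO`, the methylamino analogue, also reaches only the limit > 100000 nM in this assay. The step that the two limits leave unreadable from compound 2 to compound 3 is therefore unreadable, its size hidden by the two limits. Compound 3 thus stands at the floor of what this assay can report, alongside the two other compounds; the limit of > 100000 nM in this assay, at which 3 of the 3 values shown sit, gathers every value shown. Compound 4 `OCCOCn1c(SCc2ccccc2)nc2c(Cl)cc(Cl)cc21` differs from compound 3 by benzylsulfanyl in place of methylamino on an aromatic carbon. Within the data shown here, no measured step bears on this exchange: the only step recorded runs from one limit to another and gives no size. The change is far larger than that single step, so compound 4 could move either way, yet the three limits give no ground to expect a measurable inhibitor. Compound 4 is estimated at 100000 nM, within 20000 nM to 500000 nM, and the step of a number no higher from compound 3 to compound 4 (the limit leaves the size open) is expected to stay within the scatter.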

Compound 4, half-maximal inhibitory concentration: > 100000 nM
Compound 4: a limit, no number; the forecaster's own chance of this, stated with the estimate: 70%; the middle value lies on the limit itself.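

Compound 4 returns only a limit in this assay, as compound 2 and compound 3 do, so neither step to compound 4 can be read: the limit of > 100000 nM in this assay, at which 4 of the 4 values shown sit. The compounds shown leave open how large the effect of benzylsulfanyl in place of amino or methylamino is, and which change to the shared core would give a readable value.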